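Phenyl in Place of Ethoxy on an Unmeasured Third Compound

A few compounds are considered here, and "the series" means these few. Any claim that something is new, unique, unknown or untested is made for them only; others in the source may bear on it.

Measured so far:
compound 1, `CCO/C(O)=C\c1nncc2cncn12` — > 48000 nM
compound 2, `COCc1nc(Br)c2cnnc(O)n12` — > 48000 nM

Of the compounds shown here, two have been tested in a functional assay for inhibition, with Homo sapiens as the target; on this read-out lower numbers stand for stronger inhibition and higher numbers for weaker inhibition. For compound 1 the reading is a limit of the assay rather than a number, > 48000 nM. For compound 2 the reading is also a limit, > 48000 nM. Among the measured compounds shown here, no step between compound 1 and compound 2 can be drawn, since they differ in more than one place; all the two readings show is that both sit at the same limit. Compound 1 thus has no measured strength at all: it stands at the limit of > 48000 nM in this assay, at which 2 of the 2 values shown sit.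

The next compound is compound 3, `O/C(=C/c1nncc2cncn12)c1ccccc1`. It differs from compound 1 in one place: phenyl in place of ethoxy on a double-bonded chain carbon bound to a double-bonded chain carbon and an oxygen on an unsaturated carbon. For the measured compounds named here, with no measured step to lean on, and because compound 1 rests at the limit of > 48000 nM in this assay, at which 2 of the 2 values shown sit, the expected step from compound 1 to compound 3 is a number no higher from compound 1 to compound 3 (the limit leaves the size open), that is, no change beyond the scatter. Compound 3 is therefore estimated at 48000 nM, in a range from 12000 nM to 200000 nM, most likely again reported only as a limit.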

Compound 3, half-maximal inhibitory concentration: 38000 nM
The estimate for compound 3 lay 1.3-fold (0.10 log units) above the measured number; the measured number falls inside the stated range.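

In this assay, among the compounds shown here, compound 3 is the first compound here to give an actual number, 38000 nM, so a group at this place on the chain can now be read on the scale and not only at its end. Compound 1 gives > 48000 nM, which is a limit of the assay and not a number. Phenyl in place of ethoxy gives an at least 1.2-fold lower number from compound 1 to compound 3 (0.10 log units; that floor lies within the scatter), and the true size of this step stays unknown because one end of it is still a limit: the limit of > 48000 nM in this assay, at which 2 of the 3 values shown sit.

The compounds shown do not tell whether the reading of compound 3 depends on the aromatic ring itself or on the loss of the ethoxy oxygen, and a plain cyclohexyl ring on the same carbon would be the natural group to separate those two readings. They also leave open what an amine, a longer chain such as butoxy, or a phenyl ring carrying a methoxy group would give at this place in this assay.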